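The source may report more compounds than this note shows. Statements on the series, on what has been measured and on what is new or still open speak of the compounds shown alone.

Measured so far in a functional assay on 4T1 cells (Mus musculus) for cytotoxicity, read by MTT assay, with a stated time of 48 h; on this read-out lower numbers stand for stronger inhibition and higher numbers for weaker inhibition:
- Compound 1 `COc1cc(OC)c(OC)cc1/C=C/C(=O)/C=C/c1cc2ccccc2nc1Cl`: 1810 nM
- Compound 2 `COc1ccc(/C=C/C(=O)/C=C/c2cc3ccccc3nc2Oc2cccc(Cl)c2)cc1OC`: > 10000 nM (a limit)

The entry for compound 2, > 10000 nM, is a limit and not a number. Its place on the scale is therefore known only as a bound.

The next entry is compound 3 `COc1cc(OC)c(OC)cc1/C=C/C(=O)/C=C/c1cc2ccccc2nc1Oc1cccc(Cl)c1`, which differs from compound 2 by one change: methoxy in place of hydrogen on an aromatic carbon. In short, methoxy takes the place of hydrogen on an aromatic carbon, turning 3,4-dimethoxyphenyl into 2,4,5-trimethoxyphenyl.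

Within the data shown here, no measured step isolates this change, so any expectation is loose. In this assay, compound 1 gives 1810 nM, which shows that a numeric reading is possible within this small set. A modest gain in potency is expected, although compound 3 could also stay at the limit. The estimated move is an at least 1.6-fold lower number from compound 2 to compound 3 (0.22 log units; that floor lies within the scatter). For compound 3 the estimate is 6000 nM, with an expected range of 1500 nM to 20000 nM.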

Compound 3, half-maximal inhibitory concentration: > 10000 nM
Compound 3: no number, only a limit; the forecaster's own chance of this, stated with the estimate: 35%; at least 1.6-fold (0.22 log units) between middle value and limit.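

In this assay compound 3 reads > 10000 nM, which is a limit and not a number, so the 2,4,5-trimethoxyphenyl group does not bring the 3-chlorophenoxy series to a numeric reading. The step that adds this methoxy cannot be read, with both compounds at the same limit: the limit of > 10000 nM in this assay, at which 2 of the 3 values shown sit. Among these compounds, with 2,4,5-trimethoxyphenyl held constant, 3-chlorophenoxy in place of chloro on an aromatic carbon gives an at least 5.5-fold higher number from compound 1 to compound 3 (0.74 log units; beyond the scatter), so this pair places a clear loss of potency at that carbon, the first single-place change here with a readable direction.

On these data alone, whether the added methoxy has any effect in this assay stays open, as neither 3-chlorophenoxy compound has a numeric value. Also open, as far as these compounds go, is whether an amine or a carboxylic acid in place of chloro on that carbon would give a numeric reading.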